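Methyl to Chloro on the Outer Phenyl Ring

The compounds below may be only part of what the source reports. "The series", "measured", "known", "first", "only" and "open" are said of these compounds alone.

Of the compounds shown here, three sharing one core have been tested in a functional assay on SGC-7901 cells (Homo sapiens) for antiproliferative activity, read by MTT assay, with a stated time of 24 h; on this read-out higher numbers stand for weaker inhibition and lower numbers for stronger inhibition. Compound 1 `Cc1ccc(-n2cc(-c3ccccc3NS(=O)(=O)c3c[nH]c(=O)[nH]c3=O)nn2)cc1` gives 6390 nM. Compound 2 `O=c1[nH]cc(S(=O)(=O)Nc2ccccc2-c2cn(-c3ccc(F)cc3)nn2)c(=O)[nH]1` carries fluoro where compound 1 carries methyl; in this assay compound 2 gives only a limit of the assay, > 20000 nM. Compound 3 `Cc1ccc(-n2cc(-c3ccc(NS(=O)(=O)c4c[nH]c(=O)[nH]c4=O)cc3)nn2)cc1`, in which the sulfonamide-bearing ring is attached differently, gives 8350 nM. That places compound 3 alongside compound 1, the two numbers lying within the scatter of each other, while the remaining value is a limit.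

Compound 4 `O=c1[nH]cc(S(=O)(=O)Nc2ccc(-c3cn(-c4ccc(Cl)cc4)nn3)cc2)c(=O)[nH]1` has not yet been measured. It differs from compound 3 by chloro in place of methyl on an aromatic carbon. Among the compounds with values here, the one measured step that resembles this change is the exchange of methyl for fluoro, which gave an at least 3.1-fold higher number from compound 1 to compound 2 (0.49 log units; beyond the scatter), so a halogen in place of methyl on that ring has so far meant weaker inhibition, with compound 2 reaching (the limit of > 20000 nM in this assay, at which 1 of the 3 values shown sits). On that basis compound 4 is expected to show a weaker inhibition than compound 3, roughly a 1.8-fold higher number from compound 3 to compound 4 (0.25 log units; within the scatter), though with a single precedent the size is uncertain. The estimate for compound 4 is 15000 nM, with a range from 6000 nM to 40000 nM.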

Compound 4, half-maximal inhibitory concentration: 1830 nM
Compound 4: the middle estimate sits 8.2-fold (0.91 log units) above what was measured; measured number outside the range, below it.
By their numbers in this assay, from the lowest: compound 4; then compounds 1 and 3 (each within the scatter of the next). At a limit, above all of these: compound 2.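

Exchanging 4-methylphenyl for 4-chlorophenyl gives a 4.6-fold lower number from compound 3 to compound 4 (0.66 log units; beyond the scatter) in this assay, so a halogen at this position can go with stronger inhibition and not only with weaker. The earlier fluoro step gave an at least 3.1-fold higher number from compound 1 to compound 2 (0.49 log units; beyond the scatter) and ran the opposite way, so across these two pairs, halogen in place of methyl on this ring has no single direction. No measurement shown accounts for the stronger inhibition of compound 4.

The two steps differ both in the halogen and in how the sulfonamide-bearing ring is attached, so these compounds cannot tell whether the change of direction comes from chloro versus fluoro or from the attachment. Going by these compounds, it also remains open how bromo, methoxy or an amine on the same aromatic carbon would compare with methyl and chloro in this assay.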